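The source may report more compounds than this note shows. Statements on the series, on what has been measured and on what is new or still open speak of the compounds shown alone.

Compound 2 `Cc1nc(Nc2cccc(Cl)c2)sc1C(=O)/C=C/c1ccc(Cl)cc1` is the point from which the other three compounds in this set are reached by single changes. In a functional assay on PC-3 cells (Homo sapiens) for cytotoxicity, read by MTT assay (on this read-out higher numbers stand for weaker inhibition and lower numbers for stronger inhibition), compound 2 gives > 25000 nM, a value that is a limit of the assay rather than a number.

Compound 1 `Cc1ccc(Nc2nc(C)c(C(=O)/C=C/c3ccc(Cl)cc3)s2)cc1` differs from compound 2 by 4-methylphenyl in place of 3-chlorophenyl on a nitrogen on an aromatic ring. In this assay compound 1 gives > 25000 nM, again a limit of the assay. The step that this change makes is a step that the two limits leave unreadable from compound 2 to compound 1.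

Compound 3 `COc1cccc(/C=C/C(=O)c2sc(Nc3cccc(Cl)c3)nc2C)c1` keeps the nitrogen substituent of compound 2 but changes the other end of the molecule: 3-methoxyphenyl in place of 4-chlorophenyl on a double-bonded chain carbon bound to a double-bonded chain carbon. In this assay compound 3 gives > 25000 nM, which is also a limit of the assay. The step is a step that the two limits leave unreadable from compound 2 to compound 3. Within the data shown here, all three measured values therefore share one feature, (the limit of > 25000 nM in this assay, at which 3 of the 3 values shown sit), and no step between them can be sized.

Compound 4 `COc1cccc(/C=C/C(=O)c2sc(Nc3ccc(C)cc3)nc2C)c1` has not yet been measured. It stands to compound 3 as compound 1 stands to compound 2: 4-methylphenyl in place of 3-chlorophenyl on a nitrogen on an aromatic ring. The place is the same word for word, so this is the same change, made on the core of compound 3 instead of the core of compound 2. The earlier instance left the step unreadable, and the expected step from compound 3 to compound 4 is a step that the limit leaves unreadable from compound 3 to compound 4, resting on the unreadable a step that the two limits leave unreadable from compound 2 to compound 1 and on compound 3 sitting at > 25000 nM. The estimate for compound 4 in this assay is 35000 nM, with a range from 10000 nM to 120000 nM, and most likely the assay will again report only a limit.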

Compound 4, half-maximal inhibitory concentration: > 25000 nM
Compound 4: no number, only a limit; the forecaster's own chance of this, stated with the estimate: 85%; the middle value lies beyond the limit too.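

In this assay compound 4 gives > 25000 nM, which is a limit of the assay and not a number. Among these compounds, no step from compound 3 or compound 1 to compound 4 can be read, and all four compounds share one feature: the limit of > 25000 nM in this assay, at which 4 of the 4 values shown sit. The compounds shown leave open how strongly any of them inhibits these cells, and whether either change alters that inhibition at all.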